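The compounds below may be only part of what the source reports. "The series", "measured", "known", "first", "only" and "open" are said of these compounds alone.

Compound 1 `CCCCCN(CCCCC)C(=O)N1CCN(C(=O)N(c2ccccc2)c2cccc(Br)c2)[C@H](C(=O)O)C1` gives 0.6 nM in an assay for inhibition of Type-2 angiotensin II receptor (Rattus norvegicus); on this read-out higher numbers stand for weaker inhibition and lower numbers for stronger inhibition; compound 2 `CCCCCN(CCCCC)C(=O)N1CCN(C(=O)N(c2ccccc2)c2cccc(C)c2)[C@H](C(=O)O)C1` gives 0.7 nM in this assay; compound 3 `CCCCCN(CCCCC)C(=O)N1CCN(C(=O)N(c2ccccc2)c2cccc(OC)c2)[C@H](C(=O)O)C1` gives 7.8 nM in this assay.

Compound 3 stands highest of the three numbers, with both a 13-fold higher number from compound 1 to compound 3 (1.11 log units; beyond the scatter) and an 11-fold higher number from compound 2 to compound 3 (1.05 log units; beyond the scatter) beyond the scatter. Compound 4 `CCCCCN(CCCCC)C(=O)N1CCN(C(=O)N(c2ccccc2)c2ccc(C(=O)OCC)cc2)[C@H](C(=O)O)C1` carries the change (4-(ethoxycarbonyl)phenyl in place of 3-methoxyphenyl on an amide-type nitrogen). Going by the values given here, no measured step swaps this whole group, so none bears on it directly; the two steps leading to compound 3 show only that the group on this nitrogen can move the number by a large amount. The estimate for compound 4 is therefore uncertain and is set between the measured values, expected at 3 nM within 0.4 nM to 30 nM, an expected step of a 2.6-fold lower number from compound 3 to compound 4 (0.41 log units; beyond the scatter).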

Compound 4, half-maximal inhibitory concentration: 35 nM
Estimate against measurement, compound 4: 12-fold (1.07 log units) below; measured number outside the range, above it.
By their numbers in this assay, from the lowest: compounds 1 and 2 (each within the scatter of the next); then compound 3; then compound 4.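

Measured in this assay the 4-(ethoxycarbonyl)phenyl group gives a 4.5-fold higher number from compound 3 to compound 4 (0.65 log units; beyond the scatter) and also a 50-fold higher number from compound 2 to compound 4 (1.70 log units; beyond the scatter) and a 58-fold higher number from compound 1 to compound 4 (1.77 log units; beyond the scatter) which leaves compound 4 with the highest number of the four. So this nitrogen tolerates less here than any earlier group suggested, although the change alters both the substituent and where it sits on the ring, and the step cannot be assigned to either alone.

Still open, going by these compounds, is how a carboxylic acid or an amine on this ring would read. Nothing shown here explains the rise.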